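The source may hold more compounds than are shown below. What is called first, only, known or untested is meant among the compounds shown, and "the series" means these compounds.

Measured compounds:
Compound 1 `CNc1nc(C)c(-c2nc3ccccc3s2)c(N[C@@H]2C[C@H](CO)[C@@H](O)[C@H]2O)n1` gives > 25000 nM in an ADME assay on cells (Homo sapiens) for cytotoxicity, read by polymerase chain reaction, with a stated time of 3 days (a lower number here means that less compound is tolerated, a higher number that more compound is tolerated), a limit of the assay rather than a number.
Compound 2 `CCCNc1nc(C)c(-c2nc3ccccc3s2)c(N[C@@H]2C[C@H](CO)[C@@H](O)[C@H]2O)n1` gives > 25000 nM in this assay, again a limit and not a number.
Compound 3 `COCCNc1nc(C)c(-c2nc3ccccc3s2)c(N[C@@H]2C[C@H](CO)[C@@H](O)[C@H]2O)n1` gives 21000 nM in this assay.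

Among the measured compounds shown here, compound 3 thus holds the only real number among the three; the other two values are limits, as the shared limit of > 25000 nM in this assay, at which 2 of the 3 values shown sit, shows. Compound 4 `Cc1nc(NCCC(F)(F)F)nc(N[C@@H]2C[C@H](CO)[C@@H](O)[C@H]2O)c1-c1nc2ccccc2s1` differs from compound 3 by trifluoromethyl in place of methoxy on a saturated chain carbon, two bonds along the chain from a nitrogen on an aromatic ring. The measured steps that touch this site are an at least 1.1-fold lower number from compound 2 to compound 3 (0.07 log units; that floor lies within the scatter) and an at least 1.1-fold lower number from compound 1 to compound 3 (0.07 log units; that floor lies within the scatter), both of them floors that lie within the scatter, while a step that the two limits leave unreadable from compound 1 to compound 2 cannot be read at all. So the changes made at this chain so far have not moved the number beyond the scatter, and none of them involves a trifluoromethyl group, so nothing here points to a step of any particular size or direction. For compound 4 the expectation is therefore a number near that of compound 3, with the step of a 1.0-fold higher number from compound 3 to compound 4 (0.02 log units; within the scatter) estimated to stay within the scatter. Compound 4 is estimated at 22000 nM, with a range from 8000 nM to 60000 nM, and a fair chance that only a limit is reported.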

Compound 4, half-maximal cytotoxic concentration: 9000 nM
The estimate for compound 4 lay 2.4-fold (0.39 log units) above the measured number, within the range that was stated.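

Trifluoromethyl in place of methoxy gives a 2.3-fold lower number from compound 3 to compound 4 (0.37 log units; beyond the scatter), the first step at this chain in this assay that clearly lies beyond the scatter, so the group at the end of the chain can change how much compound the cells tolerate. The other two comparisons point the same way: trifluoromethyl in place of methyl gives an at least 2.7-fold lower number from compound 2 to compound 4 (0.44 log units; beyond the scatter), and 2,2,2-trifluoroethyl in place of hydrogen gives an at least 2.7-fold lower number from compound 1 to compound 4 (0.44 log units; beyond the scatter), and as both are floors, the true steps may be larger. Compound 4 is therefore the least tolerated of the four, with its steps to all the others beyond the scatter, while the others cannot be placed in order, as two of them rest on a limit: the limit of > 25000 nM in this assay, at which 2 of the 4 values shown sit.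

The compounds shown do not tell whether the lower number comes with the fluorine atoms themselves or with the loss of the methoxy oxygen, as only one fluorinated chain appears here. They also leave open how a chain ending in a hydroxyl, an amine or a carboxylic acid, or a longer chain ending in trifluoromethyl, would behave in this assay.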